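Toward Compound 4: Exchanging the Chain-End Group

The source may report more compounds than this note shows. Statements on the series, on what has been measured and on what is new or still open speak of the compounds shown alone.

Measured in a toxicity assay on HEK-293T cells (Homo sapiens) for cytotoxicity, read by MTT assay, with a stated time of 72 h; on this read-out higher numbers stand for weaker inhibition and lower numbers for stronger inhibition:
- compound 1 `CN1CCN(CCCCn2c3c(c4ccccc42)C(=O)c2c[n+]([O-])c4ccccc4c2C3=O)CC1`: 100 nM
- compound 2 `O=C1c2c[n+]([O-])c3ccccc3c2C(=O)c2c1c1ccccc1n2CCCCN1CCNCC1`: 760 nM
- compound 3 `CN1CCN(CCCCCCn2c3c(c4ccccc42)C(=O)c2c[n+]([O-])c4ccccc4c2C3=O)CC1`: 5800 nM

Of these three, compound 3 stands highest in this assay, at 5800 nM, and so shows the weakest inhibition. The next compound, compound 4 `O=C1c2c[n+]([O-])c3ccccc3c2C(=O)c2c1c1ccccc1n2CCCN1CCC(O)CC1`, has not yet been measured. The change to it is 4-hydroxypiperidin-1-yl in place of 3-(4-methylpiperazin-1-yl)propyl on a saturated chain carbon, three bonds along the chain from an aromatic nitrogen. In words, 4-hydroxypiperidin-1-yl stands in place of 3-(4-methylpiperazin-1-yl)propyl on a saturated chain carbon, three bonds along the chain from an aromatic nitrogen.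

Among the compounds with values here, two measured steps concern the same stretch of chain. The large 58-fold higher number from compound 1 to compound 3 (1.76 log units; beyond the scatter) and the modest 7.6-fold higher number from compound 2 to compound 3 (0.88 log units; beyond the scatter) both arrive at compound 3 through 2-(4-methylpiperazin-1-yl)ethyl, and both raise the number. The change to compound 4 removes the group that contains this unit, so a move back toward lower numbers seems likely. The modest 7.6-fold higher number from compound 1 to compound 2 (0.88 log units; beyond the scatter) shows that a change at the far ring alone can also shift the value. Within the data shown here, no measured compound carries 4-hydroxypiperidin-1-yl, so the size of the move remains uncertain.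

The expected result is a modest to large a 9.7-fold lower number from compound 3 to compound 4 (0.99 log units; beyond the scatter). For compound 4 the estimated value is 600 nM, with an expected range of 120 nM to 3000 nM.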

Compound 4, half-maximal inhibitory concentration: 170 nM
Estimate against measurement, compound 4: 3.5-fold (0.55 log units) above, within the range that was stated.
By their numbers in this assay, from the lowest: compounds 1 and 4 (each within the scatter of the next); then compound 2; then compound 3.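

In this assay, a chain end carrying 4-hydroxypiperidin-1-yl, which has one hetero atom in its six-membered ring and one hydrogen-bond donor, gives a 34-fold lower number from compound 3 to compound 4 (1.53 log units; beyond the scatter) and a 4.5-fold lower number from compound 2 to compound 4 (0.65 log units; beyond the scatter), so this position tolerates a chain end without a piperazine ring and still gives a low number. Against the most closely matched low-number compound, the exchange gives a 1.7-fold higher number from compound 1 to compound 4 (0.23 log units; within the scatter), which leaves the two indistinguishable, so the 4-methylpiperazine of compound 1 is not the only chain end that reaches this level of cytotoxicity among the compounds shown. Nothing available here explains these differences.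

The hydroxyl cannot be separated from the ring and the chain in these comparisons, since compound 4 differs from each of the other compounds by more than the hydroxyl alone, and a plain piperidin-1-yl, a 4-methoxypiperidin-1-yl or a morpholin-4-yl at the same chain end would be needed to show what the hydroxyl contributes. Going by these compounds, how 4-hydroxypiperidin-1-yl behaves on a longer chain also remains open, which matters given how far the value moves between the chains of compound 1 and compound 3.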